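The source may report more compounds than this note shows. Statements on the series, on what has been measured and on what is new or still open speak of the compounds shown alone.

Measured compounds in a functional assay on KG-1 cells (Homo sapiens) for cytotoxicity, read by luminescence and CellTiter-Glo, with a stated time of 3 days; a lower number here means a stronger inhibitor, a higher number a weaker inhibitor:
- compound 1, `CN(C(=O)c1cc(F)ccc1O)c1ccc(C#N)cc1`: > 10000 nM, which is a limit of the assay and not a number.
- compound 2, `O=C(Nc1ccc(Cl)c(Br)c1)c1cc(Cl)ccc1O`: 680 nM
- compound 3, `N#Cc1ccc(NC(=O)c2ccc(-c3cccnc3)cc2O)cc1`: 7940 nM

Compound 3 stands at the highest of the two numbers shown; compound 2 sits at a lower number, and that gap lies beyond the scatter. For compound 1 only the limit is known (the limit of > 10000 nM in this assay, at which 1 of the 3 values shown sits).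

Compound 4, `N#Cc1ccc(NC(=O)c2ccc(Cl)cc2O)cc1`, is not yet measured. It differs from compound 3 in one place: chloro in place of pyridin-3-yl on an aromatic carbon. The place is on an aromatic carbon of the six-membered carbon-only ring, meta to a hydroxy group and para to a large group. Compound 2 also carries chloro at that place, with a different amide partner, and gives the lower of the two numbers; compound 1 carries fluoro there together with a methylated amide and gives only a limit. The series is too small to fix a pattern, so only a moderate step down is expected from compound 3 to compound 4, of about a 2.6-fold lower number from compound 3 to compound 4 (0.42 log units; beyond the scatter). Compound 4 is thus estimated at 3000 nM, with a range from 800 nM to 10000 nM.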

Compound 4, half-maximal inhibitory concentration: 1920 nM
Beside the measured number, compound 4's estimate is 1.6-fold (0.19 log units) above it, and the stated range covers the measured number.
By their numbers in this assay, from the lowest: compound 2; then compound 4; then compound 3. At a limit, above all of these: compound 1.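

With the amide partner and the rest of the shared core held fixed, this position can now be read through a direct pair. In this assay chloro in place of pyridin-3-yl gives a 4.1-fold lower number from compound 3 to compound 4 (0.62 log units; beyond the scatter), so at this aromatic carbon, meta to a hydroxy group and para to a large group, a six-membered aromatic ring is not needed to reach the lower number of this pair. Nothing in the data at hand accounts for the size or direction of this step.

On these data alone, only these two groups can be compared at this place, so it remains open how an amine, a methoxy group or a carboxylic acid there would move the number. Also open, as far as these compounds go, is whether the same step would appear with a different amide partner.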